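A Small Swap on a Stable Pair

The source may report more compounds than this note shows. Statements on the series, on what has been measured and on what is new or still open speak of the compounds shown alone.

Measured so far in an ADME assay on microsomes from liver (Mus musculus) for metabolic stability, read by HPLC, with a stated time of 30 min; on this read-out lower numbers stand for a less stable compound and higher numbers for a more stable compound
compound 1 (`O=C(Nc1ccc(-n2cccn2)cc1)C(=O)c1c[nH]c2ccccc12`) gives 93.6%
compound 2 (`COc1ccc(NC(=O)C(=O)c2c[nH]c3cc(C)ccc23)cc1`) gives 89.1%

The numbers for compound 2 and compound 1 lie within the usual scatter of each other, so they cannot be ranked. In both cases, most of the compound was still present at the end of the test.

The next compound to be measured is compound 3 (`Cc1ccc(NC(=O)C(=O)c2c[nH]c3cc(C)ccc23)cc1`). It keeps the rest of compound 2 and changes one group (methyl in place of methoxy on an aromatic carbon), with methyl in place of methoxy on an aromatic carbon, para to a large group.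

For the measured compounds named here, no measured pair shows what this exchange does on its own in this assay and so any forecast must be cautious. Compound 2 at 89.1% is the starting point. Only a small step is expected, none beyond the scatter, with a slight lean downward. The estimated change is a number 4.1 percentage points lower from compound 2 to compound 3 (within the scatter) in this forecast. Two compounds reveal little about a single group, so the range is kept wide. The estimate for compound 3 is 85% and the expected range runs from 70% to 97% here.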

Compound 3, percent of the compound remaining: 90.2%
Compound 3: the middle estimate sits 5.2 percentage points below what was measured, and the stated range covers the measured number.
By their numbers in this assay, from the lowest: compounds 2, 3 and 1 (each within the scatter of the next).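

In this assay the exchange of methoxy for methyl on an aromatic carbon, para to a large group, gives a number 1.1 percentage points higher from compound 2 to compound 3 (within the scatter) and so offers the first view of one change made on its own. The step lies within the usual scatter, so removing the oxygen and its hydrogen-bond acceptor, and going from 2 heavy atoms to 1, leaves no readable mark on the amount of compound remaining. This pair therefore shows that the methoxy oxygen is not required for most of the compound to survive the test, although the data offer no explanation for this result.

On these data alone, it remains open whether a much different group at this same place, such as an amine or a carboxylic acid, would leave the reading just as undisturbed. It is also unknown whether the exchange of methoxy for methyl would behave the same way on a less stable compound, where a shift would have more room to appear.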